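Cytotoxicity notes: benzyloxy for acetyl on the biaryl

The source may report more compounds than this note shows. Statements on the series, on what has been measured and on what is new or still open speak of the compounds shown alone.

Measured compounds:
- compound 1 `CC(C)N(Cc1cccc(OCCCCCC(=O)O)c1)C(=O)c1ccc(-c2cccc(OCc3ccccc3)c2)cc1`: > 26000 nM
- compound 2 `CCOC(=O)CCCCCOc1cccc(CN(C(=O)c2ccc(-c3cccc(C(C)=O)c3)cc2)C(C)C)c1`: > 26000 nM

Compound 2 `CCOC(=O)CCCCCOc1cccc(CN(C(=O)c2ccc(-c3cccc(C(C)=O)c3)cc2)C(C)C)c1` carries an acetyl group on the outer ring of its biaryl and an ethyl ester at the end of its chain. In an ADME assay on HepG2 cells (Homo sapiens) for cytotoxicity, read by CellTiter-Glo and resazurin assay, with a stated time of 72 h (on this read-out higher numbers stand for an effect only at larger amounts of compound and lower numbers for an effect already at smaller amounts), compound 2 gives > 26000 nM, which is a limit of the assay and not a number. Compound 1 `CC(C)N(Cc1cccc(OCCCCCC(=O)O)c1)C(=O)c1ccc(-c2cccc(OCc3ccccc3)c2)cc1`, the free acid with a benzyloxy group on the same ring, also stops at a limit in this assay, > 26000 nM. Both values shown therefore sit at the same ceiling (the limit of > 26000 nM in this assay, at which 2 of the 2 values shown sit), and compound 2 cannot be placed above or below compound 1 on what is shown.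

Compound 3 `CCOC(=O)CCCCCOc1cccc(CN(C(=O)c2ccc(-c3cccc(OCc4ccccc4)c3)cc2)C(C)C)c1` differs from compound 2 by benzyloxy in place of acetyl on an aromatic carbon, on an aromatic carbon meta to a large group; the ethyl ester is kept. For the measured compounds named here, no step between measured compounds is available for this change. Since compound 1, which already holds the benzyloxy group, only reaches > 26000 nM, no step beyond the scatter is expected in this assay from compound 2 to compound 3, and a further limit is the most likely outcome.

Compound 3 is estimated at 30000 nM, within 15000 nM to 60000 nM, the expected step being a step that the limit leaves unreadable from compound 2 to compound 3.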

Compound 3, half-maximal effective concentration: > 26000 nM
Compound 3: no number, only a limit; the forecaster's own chance of this, stated with the estimate: 85%; the middle value does not contradict the limit.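

In this assay compound 3 gives > 26000 nM, a limit and not a number. No step can be read between compound 3 and compound 2 or compound 1, all three sitting at one ceiling: the limit of > 26000 nM in this assay, at which 3 of the 3 values shown sit.

The compounds shown leave open whether benzyloxy in place of acetyl, or ethyl in place of hydrogen on the oxygen next to a carbonyl group, shifts this read-out at all.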